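Solubility at low pH across the shared core

The source may report more compounds than this note shows. Statements on the series, on what has been measured and on what is new or still open speak of the compounds shown alone.

Compound 1 `CS(=O)(=O)c1cccc(-c2ccc3ncc(-c4ccc(S(=O)(=O)N5CCNCC5)cc4)n3n2)c1` in a physicochemical assay for solubility, at pH 2 (on this read-out lower numbers stand for lower solubility and higher numbers for higher solubility), gives 166000 nM. Compound 3 `CS(=O)(=O)c1cccc(-c2ccc3ncc(-c4ccc(N)nc4)n3n2)c1` in this assay gives 192000 nM. These two numbers sit within the scatter of each other, so compound 1 is the lower of the two numbers only on paper, and no order between compound 1 and compound 3 is claimed. Compound 2 `CS(=O)(=O)c1ccc(-c2cnc3ccc(-c4cncc(C(F)(F)F)c4)nn23)cc1` in this assay gives only a limit, < 5000 nM, and not a number (the limit of < 5000 nM in this assay, at which 1 of the 3 values shown sits). Going by the values given here, no pair of measured compounds differs in a single place, so nothing measured here speaks to what one change alone does.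

Compound 4 `CS(=O)(=O)c1cccc(-c2ccc3ncc(-c4ccc(S(=O)(=O)CCCN)cc4)n3n2)c1` has not yet been measured in this assay. It differs from compound 1 in one place: 3-aminopropyl in place of piperazin-1-yl on a sulfonyl sulfur. A six-membered non-aromatic ring with 2 hetero atoms leaves and a group with no ring enters, on the sulfonyl sulfur whose other neighbour is an aromatic carbon. Among the compounds with values here, no measured pair tests this exchange. The step expected in this assay is a 1.1-fold higher number from compound 1 to compound 4 (0.06 log units; within the scatter), that is, none beyond the scatter, with at most a slight lean upward. Compound 4 is estimated at 190000 nM in this assay, with a range from 75000 nM to 480000 nM.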

Compound 4, solubility: > 200000 nM
Compound 4: no number, only a limit; the forecaster's own chance of this, stated with the estimate: 5%; at least 1.0-fold (0.02 log units) between middle value and limit.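

In this assay, the series now has its first pair that differs in one place: 3-aminopropyl in place of piperazin-1-yl on a sulfonyl sulfur gives an at least 1.2-fold higher number from compound 1 to compound 4 (0.08 log units; that floor lies within the scatter). Compound 4 gives only a limit of the assay and not a number, > 200000 nM. With the ring gone from this place, the read-out for compound 4 does not fall under that of compound 1, so the six-membered non-aromatic ring is not required here to hold the read-out at this level, but the true size of the step cannot be read because compound 4 stands at the upper limit of the assay: the limit of > 200000 nM in this assay, at which 1 of the 4 values shown sits.

The compounds shown leave open whether the amine at the end of the chain matters at this place, since a plain propyl chain without the amine, or a carboxylic acid in its place, would separate the amine from the chain itself. From the compounds shown here alone, a longer chain carrying the same amine also remains open, and any such comparison would need a read-out that falls inside the range of this assay.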